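The compounds below may be only part of what the source reports. "The series", "measured", "known", "first", "only" and "open" are said of these compounds alone.

Measured so far in a physicochemical assay for solubility, in phosphate buffer, at pH 7.4; a higher number here means a more soluble compound, a lower number a less soluble compound:

Compound 1 `Fc1ccc(Nc2ccc3c(C4CCNCC4)c[nH]c3c2)cc1F` gives 178000 nM 
Compound 2 `N#Cc1c[nH]c2nc(Nc3ccc4c(C5CCNCC5)c[nH]c4c3)ccc12` gives 196000 nM 
Compound 3 `CN1CCC(c2c[nH]c3cc(Nc4ccc(F)c(F)c4)ccc23)CC1` gives 200000 nM 

Compound 2 lies within the scatter of both other compounds, so the three values show no order among them. The step now in view leads to compound 4 `c1cc2c(C3CCNCC3)c[nH]c2cc1Nc1ccc2c(C3CCNCC3)c[nH]c2n1` and puts piperidin-4-yl in place of cyano on an aromatic carbon in the structure of compound 2. For the measured compounds named here, only one measured step is available, a 1.1-fold higher number from compound 1 to compound 3 (0.05 log units; within the scatter), and it concerns a different change, methyl in place of hydrogen on an amine nitrogen in a ring. Going by the values given here, it therefore bears on this replacement only loosely, and no measured step covers the loss of cyano. Compound 1 and compound 3 carry no cyano, yet their values lie within the scatter of compound 2. The expected result is a 1.0-fold lower number from compound 2 to compound 4 (0.01 log units; within the scatter) and thus no step beyond the scatter in this assay in either direction. For compound 4 the estimated value is 190000 nM with an expected range from 100000 nM to 300000 nM in this measurement.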

Compound 4, solubility: 166000 nM
Estimate against measurement, compound 4: 1.1-fold (0.06 log units) above, within the range that was stated.
By their numbers in this assay, from the lowest: compounds 4, 1, 2 and 3 (each within the scatter of the next).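

In this assay, for the compounds shown here, the exchange of cyano for piperidin-4-yl gives a 1.2-fold lower number from compound 2 to compound 4 (0.07 log units; within the scatter), the first measured step at this position, on an aromatic carbon of a five-membered aromatic ring with 1 nitrogen. The earlier compounds shown here showed only a methyl on an amine nitrogen in a ring; here a six-membered non-aromatic ring takes the place of a nitrile, and the reading stays within the scatter. Nothing measured here offers an explanation for this result.

The compounds shown leave open whether a carboxylic acid or a longer chain ending in an amine at this position would also stay within the scatter. They also leave open whether the same exchange would read alike on a core without the second piperidin-4-yl group.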